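The source may report more compounds than this note shows. Statements on the series, on what has been measured and on what is new or still open speak of the compounds shown alone.

Measured so far:
Compound 1, `CC(C)C(=O)Oc1ccc2oc(/C=C/[S+](C)[O-])cc(=O)c2c1`: in a functional assay on DLD-1 cells (Homo sapiens) for cytotoxicity, with a stated time of 48 h (a higher number here means a weaker inhibitor, a lower number a stronger inhibitor), compound 1 gives 9100 nM.
Compound 2, `CCC(=O)Oc1ccc2oc(/C=C/[S+](C)[O-])cc(=O)c2c1`: in this assay compound 2 gives 9000 nM.
Compound 3, `CC(C)COc1ccc2oc(/C=C/[S+](C)[O-])cc(=O)c2c1`: in this assay compound 3 gives 5000 nM.

Compound 3 holds the lowest of these three numbers, but its separations from the other two, a 1.8-fold lower number from compound 2 to compound 3 (0.26 log units; within the scatter) and a 1.8-fold lower number from compound 1 to compound 3 (0.26 log units; within the scatter), both lie within the scatter, so the three compounds cannot really be told apart on these results. Compound 4, `CC(C)Oc1ccc2oc(/C=C/[S+](C)[O-])cc(=O)c2c1`, differs from compound 3 by isopropyl in place of isobutyl on an oxygen on an aromatic ring. For the measured compounds named here, no measured step shortens the chain on the ring oxygen itself. The closest comparison is a 1.0-fold lower number from compound 1 to compound 2 (0.00 log units; within the scatter), where one methyl was removed from a chain elsewhere in the molecule; the two exchanges of an ester for an ether on the ring oxygen, a 1.8-fold lower number from compound 1 to compound 3 (0.26 log units; within the scatter) and a 1.8-fold lower number from compound 2 to compound 3 (0.26 log units; within the scatter), also stayed within the scatter. On this basis a step no larger than the scatter is expected in this assay, with no clear direction. Compound 4 is therefore estimated at 5000 nM, with a range from 2500 nM to 10000 nM. That estimate corresponds to an expected step of no change at the digits printed from compound 3 to compound 4 (within the scatter).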

Compound 4, half-maximal inhibitory concentration: 8000 nM
For compound 4 the middle estimate is 1.6-fold (0.20 log units) below the measured one, and the stated range covers the measured number.
By their numbers in this assay, from the lowest: compounds 3, 4, 2 and 1 (each within the scatter of the next).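

The ether chain on the ring oxygen now has a step of its own: in this assay, isopropyl in place of isobutyl gives a 1.6-fold higher number from compound 3 to compound 4 (0.20 log units; within the scatter), so this small trim of the chain does not separate the two compounds. Exchanging an ester for the isopropyl ether also leaves the compounds indistinguishable, with a 1.1-fold lower number from compound 2 to compound 4 (0.05 log units; within the scatter) and a 1.1-fold lower number from compound 1 to compound 4 (0.06 log units; within the scatter), so all four groups on this oxygen fall within reach of one another. No supporting data are available to explain these results.

As far as these compounds go, whether a markedly longer chain, an amine or a carboxylic acid on this oxygen would move the number beyond the scatter remains open. So does the question of whether any change elsewhere on the shared core would matter more than these changes on the oxygen.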